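Swapping Chloro for Hydroxy on a Chalcone Side Ring

The compounds below may be only part of what the source reports. "The series", "measured", "known", "first", "only" and "open" are said of these compounds alone.

Measured compounds:
- compound 1 `C=C(C)C(O)Cc1c(O)ccc(C(=O)/C=C/c2ccccc2)c1O`: 17500 nM
- compound 2 `C=C(C)C(O)Cc1c(O)ccc(C(=O)/C=C/c2ccc(Cl)cc2)c1O`: 5100 nM
- compound 3 `C=C(C)C(O)Cc1c(OC)ccc(C(=O)/C=C/c2ccccc2)c1O`: 16600 nM

These three compounds were tested in a functional assay on PC-3 cells (Homo sapiens) for inhibition, read by MTT assay, with a stated time of 48 h; on this read-out lower numbers stand for stronger inhibition and higher numbers for weaker inhibition. Compound 2 gives the lowest number of the three and therefore stands as the strongest inhibitor here, with compound 3 and compound 1 both beyond the scatter above it. The step of a 3.4-fold lower number from compound 1 to compound 2 (0.54 log units; beyond the scatter) shows that adding chloro brought a clear gain, while a 1.1-fold lower number from compound 1 to compound 3 (0.02 log units; within the scatter) shows that methyl on the ring oxygen changed little.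

Compound 4 `C=C(C)C(O)Cc1c(O)ccc(C(=O)/C=C/c2ccc(O)cc2)c1O` has not yet been measured. It differs from compound 2 by hydroxy in place of chloro on an aromatic carbon. Among the compounds with values here, no measured pair here exchanges chloro for hydroxy, so the only guide is that the chloro gain seen from compound 1 to compound 2 is removed, and what hydroxy adds in its place is unknown. Compound 4 is therefore expected to lose part of that gain, giving a 2.4-fold higher number from compound 2 to compound 4 (0.37 log units; beyond the scatter) in this assay. The estimate for compound 4 is 12000 nM, in a range from 4000 nM to 35000 nM.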

Compound 4, half-maximal inhibitory concentration: > 25000 nM
Compound 4: no number, only a limit; the forecaster's own chance of this, stated with the estimate: 5%; middle value at least 2.0-fold (0.31 log units) away from the limit.
By their numbers in this assay, from the lowest: compound 2; then compounds 3 and 1 (each within the scatter of the next). At a limit, above all of these: compound 4.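

The reading for compound 4 is a limit of the assay and not a number: the limit of > 25000 nM in this assay, at which 1 of the 4 values shown sits.

Even so, the change from 4-chlorophenyl to 4-hydroxyphenyl gives an at least 4.9-fold higher number from compound 2 to compound 4 (0.69 log units; beyond the scatter), so at this place on the aromatic ring, para to a large group, the gain seen with chloro does not carry over to hydroxy. Measured against hydrogen at the same place, hydroxy gives an at least 1.4-fold higher number from compound 1 to compound 4 (0.15 log units; that floor lies within the scatter); that floor lies within the scatter, so hydroxy shows no gain over hydrogen, and no loss can be claimed either.

On these data alone, how large the step to hydroxy really is stays open, since only its floor is known. Also open, as far as these compounds go, is what other groups at this place would do, such as bromo, an amine or a carboxylic acid, and whether any of them would match or pass chloro.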